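The source may report more compounds than this note shows. Statements on the series, on what has been measured and on what is new or still open speak of the compounds shown alone.

Measured in a functional assay on NCI-H460 cells (Homo sapiens) for antiproliferative activity, with a stated time of 72 h; a higher number here means a weaker inhibitor, a lower number a stronger inhibitor:
- compound 1 `Nc1ncnn2c([C@@H]3O[C@H](CO)[C@@H](O)[C@H]3O)cc(C#CC3CC3)c12`: 80 nM
- compound 2 `Nc1ncnn2c([C@@H]3O[C@H](CO)[C@@H](O)[C@H]3O)cc(-c3ccc(F)cc3F)c12`: 93300 nM
- compound 3 `Cc1ccccc1-c1cc([C@@H]2O[C@H](CO)[C@@H](O)[C@H]2O)n2ncnc(N)c12`: > 100000 nM, a limit of the assay

Compound 3 therefore stands at a limit and has no exact number. Compound 4 `Nc1ncnn2c([C@@H]3O[C@H](CO)[C@@H](O)[C@H]3O)cc(-c3ccoc3)c12` differs from it in one place: furan-3-yl in place of 2-methylphenyl on an aromatic carbon. Among the compounds with values here, no measured step makes this exchange directly. The nearest evidence is two large steps beyond the scatter, a 1200-fold higher number from compound 1 to compound 2 (3.07 log units; beyond the scatter) and an at least 1200-fold higher number from compound 1 to compound 3 (3.09 log units; beyond the scatter). The step between the two phenyl groups, an at least 1.0-fold higher number from compound 2 to compound 3 (0.03 log units; that floor lies within the scatter), has a floor within the scatter. Furan-3-yl is also an aromatic ring, but a smaller one, so only a partial recovery towards compound 1 seems likely. The expected step, towards a stronger inhibitor, is an at least 20-fold lower number from compound 3 to compound 4 (1.30 log units; beyond the scatter). For compound 4 the estimated value is 5000 nM, with an expected range from 150 nM to 100000 nM.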

Compound 4, half-maximal inhibitory concentration: 1500 nM
Compound 4: the middle estimate sits 3.3-fold (0.52 log units) above what was measured, within the range that was stated.
By their numbers in this assay, from the lowest: compound 1; then compound 4; then compound 2. At a limit, above all of these: compound 3.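

An aromatic ring on this carbon need not lose nearly all activity in this assay: furan-3-yl gives a 62-fold lower number from compound 2 to compound 4 (1.79 log units; beyond the scatter) in place of 2,4-difluorophenyl and an at least 66-fold lower number from compound 3 to compound 4 (1.82 log units; beyond the scatter) in place of 2-methylphenyl. That second step is a floor, as compound 3 stands at a limit of the assay: the limit of > 100000 nM in this assay, at which 1 of the 4 values shown sits. Even so, the five-membered ring does not match the 2-cyclopropylethynyl group, with a 19-fold higher number from compound 1 to compound 4 (1.27 log units; beyond the scatter). The compounds shown leave open how a thiophene ring, an amine or a carboxylic acid would fare on this carbon. They also leave open whether a longer alkyne chain would hold the activity of compound 1.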